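Adding a Second Fluoro to Compound 3

The source may hold more compounds than are shown below. What is called first, only, known or untested is meant among the compounds shown, and "the series" means these compounds.

Values in an ADME assay on MT2 cells (Homo sapiens) for cytotoxicity, read by XTT assay, with a stated time of 4 days (on this read-out lower numbers stand for higher toxicity in this test and higher numbers for lower toxicity in this test), all three of them limits of the assay:
- Compound 1 `Cc1nc(C(NC(=O)C(=O)Nc2ccc(F)c(Cl)c2)C2CCCCN2)sc1CO`: > 77800 nM
- Compound 2 `CC(=O)c1ccc(NC(=O)C(=O)NC(c2nc(C)c(CO)s2)C2CCCCN2)cc1`: > 107000 nM
- Compound 3 `Cc1nc(C(NC(=O)C(=O)Nc2ccc(F)cc2)C2CCCCN2)sc1CO`: > 113000 nM

Compound 3 gives > 113000 nM, which is a limit and not a number. The other two compounds are also known only as limits, so the three cannot be ranked against each other.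

Compound 4 `Cc1nc(C(NC(=O)C(=O)Nc2ccc(F)cc2F)C2CCCCN2)sc1CO` differs from compound 3 by a single change, fluoro in place of hydrogen on an aromatic carbon, ortho to a large group and meta to a fluoro group. This turns 4-fluorophenyl into 2,4-difluorophenyl.

The closest measured change is a step that the two limits leave unreadable from compound 1 to compound 3, with hydrogen in place of chloro on an aromatic carbon. A second change on the same ring is a step that the two limits leave unreadable from compound 2 to compound 3, with fluoro in place of acetyl. Neither has a readable size, so neither gives a number to carry over. Compound 1 carries a chloro on that ring and is still reported only as a limit, > 77800 nM.

In this assay, the expected at least 1.0-fold lower number from compound 3 to compound 4 (0.03 log units; that floor lies within the scatter) is therefore no larger than the scatter, in neither direction. Another limit is the likeliest report. For compound 4 the estimated value is 105000 nM, with an expected range from 50000 nM to 150000 nM.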

Compound 4, half-maximal cytotoxic concentration: > 110000 nM
Compound 4 gave a limit, no number (the forecaster's own chance of this, stated with the estimate: 80%); at least 1.0-fold (0.02 log units) between middle value and limit.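

In this assay compound 4 gives > 110000 nM, which is a limit of the assay and not a number. For the compounds shown here, compound 1, compound 2 and compound 3 are also known only as limits, so no step to compound 4 can be read. These four compounds leave open whether any of the changes on this ring shifts the half-maximal cytotoxic concentration at all.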